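The source may hold more compounds than are shown below. What is called first, only, known or untested is meant among the compounds shown, and "the series" means these compounds.

Series notes. Compound 1 `COc1cc(C)c(-c2cccc(COc3ccc(S(=O)(=O)CC(=O)O)cc3)c2)c(C)c1` and compound 2 `CCOc1cc(C)c(-c2cccc(COc3ccc(S(=O)(=O)CC(=O)O)cc3)c2)c(C)c1` share one core and differ only in the chain on the aromatic oxygen. In a functional assay on CHO cells for agonist activity at Free fatty acid receptor 1 (Homo sapiens), read by FLIPR and calcium flux (a higher number here means that more compound is needed for the effect, a lower number that less compound is needed), compound 1 gives 57.5 nM while compound 2 gives 63.1 nM. Going by the values given here, the single step in hand, a 1.1-fold higher number from compound 1 to compound 2 (0.04 log units; within the scatter), lies within the scatter, so compound 2 is not separated from compound 1 on these numbers. Compound 3 `CCCOc1cc(C)c(-c2cccc(COc3ccc(S(=O)(=O)CC(=O)O)cc3)c2)c(C)c1` carries methyl in place of hydrogen on a saturated chain carbon, two bonds along the chain from an oxygen on an aromatic ring, the same kind of chain growth as that step. Among the compounds with values here, with only that step to draw on, the expected step of a 1.1-fold higher number from compound 2 to compound 3 (0.05 log units; within the scatter) is none beyond the scatter. For compound 3 the estimate in this assay is 70 nM, range 35 nM to 140 nM.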

Compound 3, half-maximal effective concentration: 69.2 nM
The estimate for compound 3 lay 1.0-fold (0.00 log units) above the measured number, and the stated range covers the measured number.
By their numbers in this assay, from the lowest: compounds 1, 2 and 3 (each within the scatter of the next).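

In this assay the ethoxy to propoxy change gives a 1.1-fold higher number from compound 2 to compound 3 (0.04 log units; within the scatter) and so a methyl on the saturated chain carbon, two bonds along the chain from the oxygen on the aromatic ring, leaves compound 3 unseparated from compound 2. Ethyl in place of hydrogen on the chain carbon bound to that oxygen gives a 1.2-fold higher number from compound 1 to compound 3 (0.08 log units; within the scatter) and so even the two additions together stay inside the scatter. Open, from the compounds shown here alone, is whether a longer chain, a branched chain or a terminal amine would still stay within the scatter of compound 1. No supporting data bear on why the chain length makes so little difference here.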